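A few compounds are considered here, and "the series" means these few. Any claim that something is new, unique, unknown or untested is made for them only; others in the source may bear on it.

Measured in a functional assay on M14 cells (Homo sapiens) for inhibition, read by sulforhodamine B assay, with a stated time of 48 h, tested at 0.1 uM; a higher number here means a weaker effect of the compound at the concentration tested, a lower number a stronger effect:
compound 1 `O=C(Nc1cccc(-n2cc(-c3ccncc3)c(-c3cc(O)cc(Cl)c3)n2)c1)Nc1ccc(Cl)c(Cl)c1` gives 93%
compound 2 `COc1cc(Cl)cc(-c2nn(-c3cccc(NC(=O)Nc4ccc(Cl)c(C(F)(F)F)c4)c3)cc2-c2ccncc2)c1` gives 96%
compound 3 `COc1cc(Cl)cc(-c2nn(-c3cccc(NC(=O)Nc4cc(C(F)(F)F)cc(C(F)(F)F)c4)c3)cc2-c2ccncc2)c1` gives 93%

All three share the same core and a urea-linked aryl, and all three read high in this assay at the single concentration used. Compound 2 gives the highest of the three numbers, but the gap to compound 1, its nearest neighbour, lies within the scatter, and so does the gap to compound 3. No order among the three can be read from these values. For the measured compounds named here, no pair of measured compounds differs in a single place, so the series offers no measured step to anchor an expectation.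

Compound 4 `COc1cc(Cl)cc(-c2nn(-c3cccc(NC(=O)Nc4cccc(C(F)(F)F)c4)c3)cc2-c2ccncc2)c1` is not yet measured. It differs from compound 2 by hydrogen in place of chloro on an aromatic carbon. The three measured numbers sit close together and the change removes a single chlorine. The expected step is a number 2 percentage points lower from compound 2 to compound 4 (within the scatter), not beyond the usual scatter. Compound 4 is expected to give 94%, with a range from 82% to 102%.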

Compound 4, a percentage reported as activity, at one concentration (the size of the read-out at that concentration, not a potency): 93%
The estimate for compound 4 lay 1 percentage points above the measured number, and the stated range covers the measured number.
By their numbers in this assay, from the lowest: compounds 1, 3, 4 and 2 (each within the scatter of the next).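

In this assay, for the compounds shown here, hydrogen in place of chloro, ortho to a trifluoromethyl group, gives a number 3 percentage points lower from compound 2 to compound 4 (within the scatter) and hydrogen in place of trifluoromethyl gives no change at the digits printed from compound 3 to compound 4 (within the scatter) as the first single-place steps. Both steps lie within the scatter, so at this one concentration neither chloro nor the extra trifluoromethyl on this aryl ring can be told apart from hydrogen. Nothing available bears on the reason for this result.

As far as these compounds go, whether an amine or a carboxylic acid on this aromatic carbon would move the number beyond the scatter stays open. Also open, from the compounds shown here alone, is whether these two changes would remain within the scatter at another concentration, since a single concentration gives no potency.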